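The source may hold more compounds than are shown below. What is called first, only, known or untested is meant among the compounds shown, and "the series" means these compounds.

Working notes on the series built on the shared core of compound 1 `COc1ccc2[nH]c(C(=O)N3CC(=O)N(Cc4ccccc4)[C@@H](CN4CCC(C)CC4)C3)cc2c1`. The variable part is the amine carried on a saturated chain carbon bound to a saturated ring carbon. In a physicochemical assay for solubility, read by spectrophotometry, in phosphate buffer, with a stated time of 2 h, at pH 7.4 (on this read-out lower numbers stand for lower solubility and higher numbers for higher solubility), compound 1 gives 93100 nM. Compound 2 `COc1ccc2[nH]c(C(=O)N3CC(=O)N(Cc4ccccc4)[C@@H](CN4CCCC4)C3)cc2c1` carries pyrrolidin-1-yl in place of 4-methylpiperidin-1-yl. In this assay compound 2 is reported only as a limit, > 25000 nM. Among the compounds with values here, the single measured step, a step that the limit leaves unreadable from compound 1 to compound 2, cannot be sized because the limit of > 25000 nM in this assay, at which 1 of the 2 values shown sits, leaves one end open.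

Compound 3 `COc1ccc2[nH]c(C(=O)N3CC(=O)N(Cc4ccccc4)[C@@H](CCN4CCC5(CC4)CC5)C3)cc2c1` differs from compound 2 by a group of 9 heavy atoms (8 carbon, 1 nitrogen; one three-membered non-aromatic ring of carbon only, one six-membered non-aromatic ring with 1 hetero atom) in place of a group of 5 heavy atoms (4 carbon, 1 nitrogen; one five-membered non-aromatic ring with 1 hetero atom), on a saturated chain carbon bound to a saturated ring carbon. Within the data shown here, no measured step bears directly on this exchange, and the one step that exists in this assay gives no readable size, so there is nothing from which to project a direction beyond the scatter. Among the measured compounds shown here, compound 2 itself stands only as a limit, so the starting point is not fixed either; the only firm number is that of compound 1. On that basis the estimate for compound 3 is 45000 nM, with a range from 12000 nM to 150000 nM. The expected step from compound 2 to compound 3 is a step that the limit leaves unreadable from compound 2 to compound 3, a figure set against a limit rather than a number.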

Compound 3, solubility: > 25000 nM
Compound 3: only a limit was reported (the forecaster's own chance of this, stated with the estimate: 30%); the middle value is on the limit's open side.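

In this assay compound 3 is reported only as a limit, > 25000 nM. No step from compound 1 or compound 2 to compound 3 can be read, because both run into the same bound: the limit of > 25000 nM in this assay, at which 2 of the 3 values shown sit.

The compounds shown leave open how the amines of compound 2 and compound 3 rank against each other and against that of compound 1.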